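The compounds below may be only part of what the source reports. "The series", "measured", "known", "first", "only" and "open" are said of these compounds alone.

Series notes. Going by the values given here, compound 1 `CCCS(=O)(=O)Nc1cccc2c1CCCC2c1c[nH]cn1` and compound 2 `CCS(=O)(=O)Nc1cccc2c1CCCC2(O)c1c[nH]cn1` share the same core and differ from each other in two places, so no single-change step between them can be drawn. In an assay on isolated protein (Cricetulus griseus) for binding affinity to Alpha-1B adrenergic receptor (Mesocricetus auratus), read by radioligand binding (on this read-out lower numbers stand for stronger inhibition and higher numbers for weaker inhibition), compound 1 gives < 10000 nM, which is a limit of the assay and not a number. In this assay compound 2 likewise gives only a limit, < 10000 nM. Among the compounds with values here, both values sit at the limit of < 10000 nM in this assay, at which 2 of the 2 values shown sit, so compound 1 can be placed no more closely than that, and no measured step exists in the set.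

The unmeasured compound 3 `CC(=O)Nc1cccc2c1CCCC2c1c[nH]cn1` differs from compound 1 in one place: acetyl in place of propylsulfonyl on a nitrogen on an aromatic ring. Within the data shown here, with no measured step available, the size of the change from compound 1 to compound 3 cannot be anchored to anything seen here; the expectation is a step that does not clearly go beyond the scatter in either direction, with a wide range to reflect the absence of any number for compound 1. Compound 3 is therefore estimated at 1500 nM, with a range from 100 nM to 10000 nM. This corresponds to an expected step that the limit leaves unreadable from compound 1 to compound 3.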

Compound 3, inhibition constant: < 10000 nM
Compound 3: no number, only a limit (the forecaster's own chance of this, stated with the estimate: 60%); the middle value lies beyond the limit too.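

No new step can be read between compound 1 and compound 3, because each gives only a limit in this assay: the limit of < 10000 nM in this assay, at which 3 of the 3 values shown sit. The compounds shown leave open what number any of them would give in this assay, and so whether acetyl in place of propylsulfonyl on a nitrogen on an aromatic ring changes the read-out at all.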